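The source may hold more compounds than are shown below. What is called first, only, known or untested is meant among the compounds shown, and "the series" means these compounds.

Measured so far in a functional assay on OVCAR-3 cells (Homo sapiens) for cytotoxicity, read by sulforhodamine B assay; on this read-out lower numbers stand for higher toxicity in this test and higher numbers for lower toxicity in this test:
compound 1 `CC1=CC[C@@H]([C@@](C)(O)CCCC(C)(C)NC(=S)N/N=C\c2ccc(O)cc2)CC1`, compound 1 gives 54400 nM.
compound 2 `CC1=CC[C@@H]([C@@](C)(O)CCCC(C)(C)NC(=S)N/N=C\c2ccccc2Cl)CC1`, compound 2 gives only a limit, > 100000 nM.

Compound 2 thus sits at the assay limit, with no number of its own (the limit of > 100000 nM in this assay, at which 1 of the 2 values shown sits). Going by the values given here, the only measured step, an at least 1.8-fold higher number from compound 1 to compound 2 (0.26 log units; that floor lies within the scatter), is itself bounded by that limit and within the scatter.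

Compound 3 `CC1=CC[C@@H]([C@@](C)(O)CCCC(C)(C)NC(=S)N/N=C(/C)c2ccccc2)CC1` carries a group of 9 heavy atoms (8 carbon, 1 nitrogen; one six-membered aromatic ring of carbon only) in place of a group of 9 heavy atoms (7 carbon, 1 nitrogen, 1 chlorine; one six-membered aromatic ring of carbon only), on an amide-type nitrogen. Among the compounds with values here, no measured step covers this exchange, and the starting point is a limit, so no direction beyond the scatter is expected in this assay; the step of a number no higher from compound 2 to compound 3 (the limit leaves the size open) is an estimate only. Compound 3 is expected at 100000 nM (range 40000 nM to 300000 nM), most likely again reported as a limit.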

Compound 3, concentration lethal to 50% of the cells: > 100000 nM
Compound 3: a limit, no number (the forecaster's own chance of this, stated with the estimate: 60%); the middle value sits exactly at the limit.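

In this assay compound 3 gives > 100000 nM, which is a limit and not a number. Going by these compounds alone, its group of 9 heavy atoms (8 carbon, 1 nitrogen) on the amide-type nitrogen gives a second exchange that leaves compound 1 as the only compound with a number, and this exchange reads only as a floor: an at least 1.8-fold higher number from compound 1 to compound 3 (0.26 log units; that floor lies within the scatter). The step between compound 2 and compound 3 cannot be read, and limits now hold most of the series: the limit of > 100000 nM in this assay, at which 2 of the 3 values shown sit.

Still open, on these data alone, is whether a group carrying an amine or a carboxylic acid in this place would give a number of its own.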